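Swapping the aryl group on the piperazine nitrogen

The source may hold more compounds than are shown below. What is called first, only, known or untested is meant among the compounds shown, and "the series" means these compounds.

Of the compounds shown here, three have been measured in a functional assay on HEK293 cells with D(4) dopamine receptor (Homo sapiens) as the target, read by FLIPR; a lower number here means that less compound is needed, a higher number that more compound is needed for the effect. Compound 1 `O/N=C(\CCN1CCN(c2ccccn2)CC1)c1ccccc1Cl` gives 24 nM, and compound 2 `O/N=C(\CCN1CCN(c2ccccn2)CC1)c1cccc(Cl)c1` gives 11.9 nM; the step of a 2.0-fold lower number from compound 1 to compound 2 (0.30 log units; within the scatter) is small. Compound 3 `CCO/N=C(\CCN1CCN(c2ccccc2OC)CC1)c1ccccc1` gives 338 nM, the highest of the three numbers. Compound 4 `CCO/N=C(\CCN1CCN(c2ncccc2C)CC1)c1ccccc1` differs from compound 3 in one place: 3-methylpyridin-2-yl in place of 2-methoxyphenyl on an amine nitrogen in a ring. Among the measured compounds shown here, no measured step covers this exchange; the only measured step, from compound 1 to compound 2, concerns a chlorophenyl group elsewhere and does not bear on it. Compounds 1 and 2 carry a pyridinyl group at this nitrogen and show lower numbers than compound 3, but they also differ in the oxime ether, so the expectation for compound 4 is uncertain and a modest move toward a lower number, a 2.8-fold lower number from compound 3 to compound 4 (0.45 log units; beyond the scatter), is estimated, giving an expected 120 nM with a range from 30 nM to 500 nM.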

Compound 4, half-maximal effective concentration: 253 nM
The estimate for compound 4 lay 2.1-fold (0.32 log units) below the measured number; the range from low to high includes it.
By their numbers in this assay, from the lowest: compounds 2 and 1 (each within the scatter of the next); then compounds 4 and 3 (each within the scatter of the next).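

In this assay, the first exchange read at this amine nitrogen in a ring gives a 1.3-fold lower number from compound 3 to compound 4 (0.13 log units; within the scatter). A six-membered aromatic ring of carbon only can thus give way to one with a hetero atom, with the group on that ring changing too, without a change beyond the scatter. No evidence is available to explain this result.

Because both parts of the exchange changed together, their separate contributions remain unresolved. Also open, going by these compounds, is how a benzyl group or an unsubstituted phenyl group would read at this nitrogen.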